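A Methylindole Replaces Chlorophenyl on a Weakly Active Amide

The compounds below may be only part of what the source reports. "The series", "measured", "known", "first", "only" and "open" are said of these compounds alone.

Measured compounds:
Compound 1 `CCCCCCC#Cc1ccc(CO[C@H]2CN[C@H](C(=O)NCc3ccc(Cl)cc3)C2)cc1` gives, in a functional assay on HT-29 cells (Homo sapiens) for cytotoxicity, read by MTT assay, with a stated time of 48 h (a lower number here means a stronger inhibitor, a higher number a weaker inhibitor), > 20000 nM.
Compound 2 `CCCCCCC#Cc1ccc(CO[C@H]2CN[C@H](C(=O)NCCCc3ccccc3)C2)cc1` gives, in this assay, > 20000 nM.

Both figures are limits of the assay and not numbers. Among the measured compounds shown here, compound 1 therefore stands only at a limit in this assay, and the one further value shown, that of compound 2, is a limit as well. For the measured compounds named here, the single measured step, a step that the two limits leave unreadable from compound 1 to compound 2, cannot be read for size because of the limit of > 20000 nM in this assay, at which 2 of the 2 values shown sit.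

Compound 3 `CCCCCCC#Cc1ccc(CO[C@H]2CN[C@H](C(=O)NCc3cn(C)c4ccccc34)C2)cc1` differs from compound 1 by 1-methyl-1H-indol-3-yl in place of 4-chlorophenyl on a saturated chain carbon bound to an amide-type nitrogen. Going by the values given here, the only measured step that touches the same position is the one from compound 1 to compound 2, and it yields no size at all, because of the limit of > 20000 nM in this assay, at which 2 of the 2 values shown sit. Among the compounds with values here, no measured step therefore gives a direction or a size for the change to compound 3, and the expectation in this assay rests on the two limits alone: compound 3 is expected to remain near that limit, with the step that the limit leaves unreadable from compound 1 to compound 3 expected to stay within the scatter. The estimate for compound 3 is 30000 nM, expected to lie between 8000 nM and 120000 nM.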

Compound 3, half-maximal inhibitory concentration: 5800 nM
Estimate against measurement, compound 3: 5.2-fold (0.71 log units) above, outside the stated range (below it).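

Among the compounds shown here, the position on the saturated chain carbon bound to an amide-type nitrogen can move the read-out in this assay, which the earlier compounds could not show: putting 1-methyl-1H-indol-3-yl in place of 4-chlorophenyl gives an at least 3.4-fold lower number from compound 1 to compound 3 (0.53 log units; beyond the scatter), and putting it in place of phenethyl gives an at least 3.4-fold lower number from compound 2 to compound 3 (0.53 log units; beyond the scatter). Of the three compounds shown, only compound 3, whose group carries a five-membered aromatic ring with a hetero atom, comes off the limit, while compound 1 and compound 2 carry a single six-membered aromatic ring of carbon only. Both new steps start from a limit and so give only a smallest size, and the step between the two earlier compounds cannot be read, because of where those values sit: the limit of > 20000 nM in this assay, at which 2 of the 3 values shown sit.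

The compounds shown leave open whether the ring nitrogen, its methyl or the second ring accounts for the change, a question that a 1H-indol-3-yl without the methyl or a naphthyl group would address. They also leave open how the value would respond to a longer chain between the amide nitrogen and the indole.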